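The source may hold more compounds than are shown below. What is called first, only, known or untested is meant among the compounds shown, and "the series" means these compounds.

In an ADME assay on HEK-293T cells (Homo sapiens) for inhibition, read by CCK-8 assay, with a stated time of 48 h, tested at 20 uM (a lower number here means less inhibition of growth, a higher number more inhibition of growth at the concentration tested), compound 1 (`COc1ccc(S(=O)(=O)Oc2ccccc2/C=C(\C#N)C(=O)Nc2nnc(-c3cccs3)s2)cc1`) gives 40% and compound 2 (`N#C/C(=C\c1ccccc1OS(=O)(=O)c1ccc([N+](=O)[O-])cc1)C(=O)Nc1nnc(-c2cccs2)s1`) gives 33%. Compound 3 (`Cc1ccc(S(=O)(=O)Oc2cccc(/C=C(\C#N)C(=O)Nc3nnc(C)s3)c2)cc1`) gives 27%, which lies within the scatter of compound 2 and beyond the scatter below compound 1. Compound 4 (`Cc1ccc(S(=O)(=O)Oc2cccc(/C=C(\C#N)C(=O)Nc3nnc(-c4ccccc4Cl)s3)c2)cc1`) has 2-chlorophenyl in place of methyl on an aromatic carbon, (2-chlorophenyl in place of methyl on an aromatic carbon). For the measured compounds named here, the only measured step, a number 7 percentage points lower from compound 1 to compound 2 (within the scatter), puts nitro in place of methoxy at a different place and lies within the scatter, so no measured step tests this change directly. The guidance is indirect: two compounds carry an aromatic ring at this place, compound 1 at 40% and compound 2 at 33%, though both also differ from compound 3 elsewhere. A modest rise in this assay, not beyond the scatter, is therefore expected. The expected step is a number 7 percentage points higher from compound 3 to compound 4 (within the scatter). The estimated value for compound 4 is 34%, with an expected range from 20% to 52%.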

Compound 4, percent growth inhibition at one concentration: 55%
Compound 4: the middle estimate sits 21 percentage points below what was measured; measured number outside the range, above it.
By their numbers in this assay, from the lowest: compounds 3, 2 and 1 (each within the scatter of the next, the first and the last beyond it); then compound 4.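

For the compounds shown here, this is the first direct reading of the position on the aromatic carbon next to the ring nitrogen and the ring sulfur. In this assay, 2-chlorophenyl in place of methyl gives a number 28 percentage points higher from compound 3 to compound 4 (beyond the scatter). The position is therefore not indifferent to its group, at least in this single pair with the rest of the structure held constant, and the step shows that growth inhibition of these cells can change with this exchange alone. No available evidence bears on what lies behind the rise.

The compounds shown leave open whether the rise goes with the added ring or with its chlorine, which a plain phenyl group would separate. Also open, going by these compounds, is how a cyclohexyl ring or an amine at this place would read, and whether the step holds on the core of compound 1.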